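The source may hold more compounds than are shown below. What is called first, only, known or untested is meant among the compounds shown, and "the series" means these compounds.

Measured so far in a functional assay on K562 cells (Homo sapiens) for antiproliferative activity, read by MTT assay, with a stated time of 48 h; a higher number here means a weaker inhibitor, a lower number a stronger inhibitor:
compound 1, `Cc1nc2ccccc2nc1Oc1ccc(C(=O)N[C@@H](C)C(=O)O)cc1`: 28100 nM
compound 2, `CC[C@@H](C)[C@H](NC(=O)c1ccc(Oc2nc3ccccc3nc2C)cc1)C(=O)O`: 30500 nM
compound 3, `CCCCCCCCCCCCNc1nc2ccccc2nc1Oc1ccc(C(=O)N[C@@H](C)C(=O)OC)cc1`: 26700 nM

Compound 2 differs from compound 1 by sec-butyl in place of methyl on a saturated chain carbon bound to an amide-type nitrogen and a carbonyl carbon; the step is a 1.1-fold higher number from compound 1 to compound 2 (0.04 log units; within the scatter). Compound 3 rests on a different core from compound 1, and that difference is not broken down here; in this assay compound 3 gives 26700 nM, and the two values lie within the scatter of each other.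

Compound 4, `CCCCCCCCCCCCNc1nc2ccccc2nc1Oc1ccc(C(=O)N[C@H](C(=O)OC)[C@H](C)CC)cc1`, is not yet measured. It carries sec-butyl in place of methyl on a saturated chain carbon bound to an amide-type nitrogen and a carbonyl carbon, the same change that separates compound 1 from compound 2, at the same place. Because a 1.1-fold higher number from compound 1 to compound 2 (0.04 log units; within the scatter) stayed within the scatter, no larger step is expected on the core of compound 3. The expected step for compound 4 is a 1.1-fold higher number from compound 3 to compound 4 (0.04 log units; within the scatter). Compound 4 is estimated at 29000 nM, with a likely range from 14000 nM to 60000 nM.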

Compound 4, half-maximal inhibitory concentration: 30800 nM
Compound 4: middle estimate off by 1.1-fold (0.03 log units), on the low side; the range from low to high includes it.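

In this assay, sec-butyl in place of methyl on a saturated chain carbon bound to an amide-type nitrogen and a carbonyl carbon gives a 1.2-fold higher number from compound 3 to compound 4 (0.06 log units; within the scatter). The change behaves alike on the two cores: the same change on two cores in this assay, a 1.1-fold higher number (0.04 log units; within the scatter) from compound 1 to compound 2 and a 1.2-fold higher number (0.06 log units; within the scatter) from compound 3 to compound 4, 1.1-fold (0.03 log units) apart, within the scatter of two such steps. Going by these compounds alone, this shows only that the change leaves the value within the scatter on both cores; it does not show that a change with a larger step would carry over in the same way, or that the result holds on any further core or in any other assay.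

From the compounds shown here alone, whether a benzyl group or a chain bearing an amine at this carbon would shift the value in this assay remains open. So does the effect of the opposite configuration at the sec-butyl stereocentre.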